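Swapping a thiourea arm for a methoxyphenyl urea

A few compounds are considered here, and "the series" means these few. Any claim that something is new, unique, unknown or untested is made for them only; others in the source may bear on it.

Measured so far in a functional assay on RS4-11 cells (Homo sapiens) for inhibition, read by CCK-8 assay, with a stated time of 48 h; on this read-out higher numbers stand for weaker inhibition and lower numbers for stronger inhibition:
- compound 1 `O=[N+]([O-])c1cccc(NC(=S)NCCNS(=O)(=O)c2ccc(-c3ccccc3OCc3ccccc3)s2)c1`: 11600 nM
- compound 2 `COc1ccc(Oc2ccc(C(C)C)cc2-c2ccsc2S(=O)(=O)NCCNC(=O)Nc2cc(Cl)cc(Cl)c2)cc1OC`: 9000 nM
- compound 3 `COc1ccc(NC(=O)NCCNS(=O)(=O)c2ccc(-c3ccccc3Oc3ccc([N+](=O)[O-])c([N+](=O)[O-])c3)s2)cc1`: 1400 nM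

Among these three, compound 1 gives the highest number in this assay, meaning the weakest inhibition. Its nearest neighbour is compound 2, whose value lies within the usual scatter of compound 1, so no order can be drawn between these two. Compound 3 is the one that stands apart, with a number well beyond the scatter below that of compound 1 and hence clearly stronger inhibition.

The next compound to consider is compound 4 `COc1cccc(NC(=O)NCCNS(=O)(=O)c2ccc(-c3ccccc3OCc3ccccc3)s2)c1`. It keeps the core of compound 1 and changes only one end of the chain: a group of 11 heavy atoms (8 carbon, 1 nitrogen, 2 oxygen; one six-membered aromatic ring of carbon only) in place of a group of 12 heavy atoms (7 carbon, 2 nitrogen, 2 oxygen, 1 sulfur; one six-membered aromatic ring of carbon only), on an amine nitrogen. For the measured compounds named here, no measured pair in this set isolates this same change, so the expectation rests on the spread of the three numbers alone. Compound 3, which also carries a methoxyphenyl carbamoyl group, gives 1400 nM, but it differs from compound 4 in other places as well, so it is only a loose guide. A modest move toward stronger inhibition is expected, of size a 1.9-fold lower number from compound 1 to compound 4 (0.29 log units; within the scatter), though it may not exceed the scatter. For compound 4 the estimated value in this assay is 6000 nM, within a range from 2000 nM to 18000 nM.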

Compound 4, half-maximal inhibitory concentration: > 20000 nM
Compound 4: only a limit was reported; the forecaster's own chance of this, stated with the estimate: 10%; at least 3.3-fold (0.52 log units) between middle value and limit.
By their numbers in this assay, from the lowest: compound 3; then compounds 2 and 1 (each within the scatter of the next). At a limit, above all of these: compound 4.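

In this assay, compound 4 gave only a limit rather than a number: the limit of > 20000 nM in this assay, at which 1 of the 4 values shown sits.

The pair differs in one place only, and the step is an at least 1.7-fold higher number from compound 1 to compound 4 (0.23 log units; that floor lies within the scatter). For the compounds shown here, on this amine nitrogen, then, putting the (3-methoxyphenyl)carbamoyl group in place of the thiourea arm of compound 1 gives no sign of stronger inhibition, which the earlier compounds, all differing in more than one place, could not show.

Going by these compounds, the true size of the gap remains unknown, since only a floor can be read from it. The compounds shown also leave open how a simple acetyl group, a carboxylic acid or a longer chain on this nitrogen would read, and whether the same swap would behave alike on a different core.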